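A few compounds are considered here, and "the series" means these few. Any claim that something is new, unique, unknown or untested is made for them only; others in the source may bear on it.

Measured compounds:

Compound 1 `C/C(=C\COC(=O)NC(C)(C)C)C1=CC(=O)C(C)(C)O1`: 2.1 ug/mL
Compound 2 `C/C(=C\C=C/C1CCCCC1)C1=CC(=O)C(C)(C)O1`: 8.4 ug/mL
Compound 3 `C/C(=C\C=C\c1ccccc1)C1=CC(=O)C(C)(C)O1`: 6.5 ug/mL

All three share the same core and differ only in the side chain carried on it. In a functional assay on MT4 cells (Homo sapiens) for inhibition (a lower number here means a stronger inhibitor, a higher number a weaker inhibitor), compound 1 gives 2.1 ug/mL, the lowest of the three numbers. Compound 3 gives 6.5 ug/mL, and compound 2 gives 8.4 ug/mL; both gaps to compound 1 lie beyond the usual scatter, so compound 1 is the strongest inhibitor of the three.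

Compound 4 `C=CCNC(=O)OC/C=C(\C)C1=CC(=O)C(C)(C)O1` is the next compound. It differs from compound 1 in one place: allyl in place of tert-butyl on an amide-type nitrogen. The carbamate itself, its carbonyl and its oxygen link to the chain, are kept; only the group on the nitrogen changes. Among the compounds with values here, no pair of measured compounds shows this kind of exchange, so nothing here tells how large its effect is. A small group swapped for a small group at the far end of the chain would be expected to move the number only slightly, if at all, in this assay.

Compound 4 is therefore expected to give about 3 ug/mL, somewhere between 1.2 ug/mL and 8 ug/mL, a step of a 1.4-fold higher number from compound 1 to compound 4 (0.15 log units; within the scatter) that is estimated to stay close to the scatter.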

Compound 4, half-maximal inhibitory concentration: 2.8 ug/mL
Compound 4: the middle estimate sits 1.1-fold (0.03 log units) above what was measured, within the range that was stated.
By their numbers in this assay, from the lowest: compounds 1 and 4 (each within the scatter of the next); then compounds 3 and 2 (each within the scatter of the next).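

Putting allyl in place of tert-butyl on an amide-type nitrogen gives, in this assay, a 1.3-fold higher number from compound 1 to compound 4 (0.12 log units; within the scatter), so the two compounds cannot be told apart. Within the data shown here, this is the first pair here that differs in one place, and it shows that this end of the carbamate chain can change its group, even gaining a double bond, without a readable shift in the number. Nothing measured on these groups accounts for this result.

Going by these compounds, what a benzyl group, a longer chain or a carboxylic acid on this nitrogen would do remains open, as does the effect of a bare hydrogen there. Also open, on these data alone, is what the carbamate link itself contributes, as compound 2 and compound 3 each differ from compound 1 in more than one place.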